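Dichlorobenzyl ethers of an allyl biphenyl diol series

This account rests on a few compounds, and the source may have more. Where it says the series, first, only, none or still open, it means among the compounds named here.

Three compounds of this series have been run in a functional assay on I10 cells (Mus musculus) for inhibition, read by MTT assay, with a stated time of 72 h; on this read-out higher numbers stand for weaker inhibition and lower numbers for stronger inhibition. Compound 1 `C=CCc1ccc(OCc2ccc(Cl)cc2Cl)c(-c2ccc(O)c(CC=C)c2)c1` gives 21100 nM. Compound 2 `C=CCc1ccc(O)c(-c2ccc(OCc3c(Cl)cccc3Cl)c(CC=C)c2)c1` gives 16600 nM, and compound 3 `C=CCc1ccc(OCc2c(Cl)cccc2Cl)c(-c2ccc(O)c(CC=C)c2)c1` gives 17200 nM. All three numbers lie within the usual scatter of one another, so no order among them can be read from this set.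

One structural change occurs twice among the compounds shown. From compound 3 to compound 1 it is 2,4-dichlorophenyl in place of 2,6-dichlorophenyl on a saturated chain carbon bound to an oxygen on an aromatic ring, and the step it made was a 1.2-fold higher number from compound 3 to compound 1 (0.09 log units; within the scatter). The same change, (2,4-dichlorophenyl in place of 2,6-dichlorophenyl on a saturated chain carbon bound to an oxygen on an aromatic ring), carries compound 2 to the not yet measured compound 4 `C=CCc1ccc(O)c(-c2ccc(OCc3ccc(Cl)cc3Cl)c(CC=C)c2)c1`. Compound 2 and compound 3 share the same atoms but joined differently; how their two cores differ is not broken down here.

Because the measured instance of this change gave only a 1.2-fold higher number from compound 3 to compound 1 (0.09 log units; within the scatter), the step from compound 2 to compound 4 in this assay is expected to be of a similar size, estimated as a 1.1-fold higher number from compound 2 to compound 4 (0.06 log units; within the scatter), resting on the value of compound 2, 16600 nM, as the starting point. For compound 4 in this assay the expected value is therefore 19000 nM, with a likely range from 9500 nM to 38000 nM.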

Compound 4, half-maximal inhibitory concentration: 10400 nM
For compound 4 the middle estimate is 1.8-fold (0.26 log units) above the measured one, and the stated range covers the measured number.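

In this assay, going from 2,6-dichlorobenzyl to 2,4-dichlorobenzyl on the core of compound 2 gives a 1.6-fold lower number from compound 2 to compound 4 (0.20 log units; within the scatter). Set beside the earlier instance of the same change, this step does not differ from it: the same change on two cores in this assay, a 1.2-fold higher number (0.09 log units; within the scatter) from compound 3 to compound 1 and a 1.6-fold lower number (0.20 log units; within the scatter) from compound 2 to compound 4, 2.0-fold (0.29 log units) apart, within the scatter of two such steps. On these two cores, then, the change carries over as a step too small to separate from the scatter, but neither step can be given a direction, so no real effect of moving the chlorine is shown on either core, and two pairs say nothing about whether the result would hold on a further core.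

Going by these compounds alone, all four compounds carry two allyl chains, one free hydroxyl and a dichlorobenzyl ether, and no step among them lies beyond the scatter, so it remains open whether any structural change moves the number by a readable amount. Replacing an allyl chain with a longer chain, an amine or a carboxylic acid, or capping the free hydroxyl as a methyl ether, would be the next places to look for such a step, and each would need a matched partner on both cores.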